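The source may hold more compounds than are shown below. What is called first, only, known or untested is meant among the compounds shown, and "the series" means these compounds.

Measured so far in a functional assay on MCF7 cells (Homo sapiens) for inhibition, read by sulforhodamine B assay; a lower number here means a stronger inhibitor, a higher number a weaker inhibitor:

Compound 1, `CCOc1ccc(NC2=CC(=O)c3c(nc4n3[C@H]3OC[C@@H](O)[C@H]3OC4)C2=O)cc1`: > 4000 nM
Compound 2, `O=C1C=C(Nc2ccccc2)C(=O)c2c1nc1n2[C@H]2OC[C@@H](O)[C@H]2OC1`: > 4000 nM
Compound 3, `CCCc1ccc(NC2=CC(=O)c3nc4n(c3C2=O)[C@H]2OC[C@@H](O)[C@H]2OC4)cc1`: 4660 nM

All three compounds share the same core and differ only in the group on the aromatic ring attached through the amine. For compound 1 this assay gives no number, only the limit > 4000 nM, which means the measurement stopped there without finding a value. The same is true of compound 2, whose result of > 4000 nM is also a limit. Compound 3 alone gives a number, 4660 nM, and it sits close to that same boundary. In all, the limit of > 4000 nM in this assay, at which 2 of the 3 values shown sit, marks where most of these results stand.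

The unmeasured compound is compound 4, `O=C1C(Nc2ccc(C(F)(F)F)cc2)=CC(=O)c2c1nc1n2[C@H]2OC[C@@H](O)[C@H]2OC1`. It differs from compound 1 in one place: trifluoromethyl in place of ethoxy on an aromatic carbon.

Among the compounds with values here, only one measured step changes the same aromatic ring, a step that the limit leaves unreadable from compound 2 to compound 3, and since it starts from a limit its size cannot be read. Within the data shown here, no step therefore gives a usable guide to the size or direction of the change from compound 1 to compound 4. Given that every compound shown sits at or near the limit, compound 4 is expected to stay in the same region, with a step that the limit leaves unreadable from compound 1 to compound 4 as the estimated step. The estimate for compound 4 is 5000 nM, within a range from 2000 nM to 15000 nM.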

Compound 4, half-maximal inhibitory concentration: > 4000 nM
Compound 4: only a limit was reported; the forecaster's own chance of this, stated with the estimate: 60%; the middle value is on the limit's open side.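

No new step can be read here: compound 1 and compound 4 are each reported in this assay only as a limit, so the change from ethoxy to trifluoromethyl has no readable size. The compounds shown leave open how strongly any group on this aromatic ring changes inhibition, since most results stand at one boundary: the limit of > 4000 nM in this assay, at which 3 of the 4 values shown sit.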